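A few compounds are considered here, and "the series" means these few. Any claim that something is new, unique, unknown or untested is made for them only; others in the source may bear on it.

Compound 1 `N#CC1=C(N)Oc2c(N)cc3nc4ccccc4nc3c2C12C(=O)N(Cc1cnnn1-c1ccc(Cl)cc1Cl)c1ccccc12`: > 50000 nM
Compound 2 `Cc1ccc(Cl)cc1-n1nncc1CN1C(=O)C2(C(C#N)=C(N)Oc3c(N)cc4nc5ccccc5nc4c32)c2ccccc21`: 17300 nM

In a functional assay on HepG2 cells (Homo sapiens) for antiproliferative activity, read by MTT assay, with a stated time of 48 h (on this read-out higher numbers stand for weaker inhibition and lower numbers for stronger inhibition), compound 2 gives 17300 nM, the only number shown. For compound 1 the value is the limit of > 50000 nM in this assay, at which 1 of the 2 values shown sits, a limit of the assay and not a number. Compound 3 `N#CC1=C(N)Oc2c(N)cc3nc4ccccc4nc3c2C12C(=O)N(Cc1cnnn1-c1ccc(F)c(Cl)c1)c1ccccc12` differs from compound 2 by 3-chloro-4-fluorophenyl in place of 5-chloro-2-methylphenyl on an aromatic nitrogen. Going by the values given here, the one measured step at this nitrogen, an at least 2.8-fold lower number from compound 1 to compound 2 (0.46 log units; beyond the scatter), shows that the aryl group here moves the read-out, but it does not cover the group entering in compound 3. A small rise in the number, a 1.4-fold higher number from compound 2 to compound 3 (0.16 log units; within the scatter), is therefore expected, with wide uncertainty. Compound 3 is estimated at 25000 nM, between 8000 nM and 60000 nM.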

Compound 3, half-maximal inhibitory concentration: > 50000 nM
Compound 3 was reported as a limit; the forecaster's own chance of this, stated with the estimate: 30%; middle value at least 2.0-fold (0.30 log units) away from the limit.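

In this assay, the aryl group on the aromatic nitrogen moves the read-out in both directions: 3-chloro-4-fluorophenyl in place of 5-chloro-2-methylphenyl gives an at least 2.8-fold higher number from compound 2 to compound 3 (0.46 log units; beyond the scatter). Compound 1 and compound 3 both stand at a limit of the assay, not a number, leaving compound 2 alone with a number: the limit of > 50000 nM in this assay, at which 2 of the 3 values shown sit. The step between the two limits cannot be read. The compounds shown leave open whether the methyl group of compound 2 accounts for its lower number, and whether an aryl group carrying an amine or a carboxylic acid would lower the number further.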